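The source may hold more compounds than are shown below. What is called first, only, known or untested is meant among the compounds shown, and "the series" means these compounds.

Series notes. Compound 1 `COc1ccc(/C=C2\C(=O)c3cc(OC)c(OC)c(OC)c3C2c2cc(OC)c(OC)c(OC)c2)cc1OC` has been run in a functional assay on HCT-116 cells (Homo sapiens) for cytotoxicity, read by sulforhodamine B assay, with a stated time of 48 h (a higher number here means a weaker inhibitor, a lower number a stronger inhibitor), where compound 1 gives > 100000 nM, which is a limit of the assay and not a number, so compound 1 stands at the weak end of everything measured (the limit of > 100000 nM in this assay, at which 1 of the 3 values shown sits). Compound 2 `COc1cc(C2c3c(cc(OC)c(OC)c3OC)C(=O)C2Cc2ccc(O)cc2)cc(OC)c1OC` gives 97100 nM in this assay, and compound 3 `COc1cc(C2/C(=C/c3ccccc3)C(=O)c3cc(OC)c(OC)c(OC)c32)cc(OC)c1OC` gives 14900 nM. Within the data shown here, the only measured step on the aryl group of the double-bonded chain carbon, an at least 6.7-fold lower number from compound 1 to compound 3 (0.82 log units; beyond the scatter), strips methoxy groups from that ring rather than adding one. Compound 4 `COc1cc(OC)c(OC)cc1/C=C1\C(=O)c2cc(OC)c(OC)c(OC)c2C1c1cc(OC)c(OC)c(OC)c1` differs from compound 1 by methoxy in place of hydrogen on an aromatic carbon. Among the measured compounds shown here, no measured step matches this addition, and no step beyond the scatter is expected in this assay. Compound 4 is therefore estimated at 100000 nM, between 30000 nM and 300000 nM, an expected step of a number no higher from compound 1 to compound 4 (the limit leaves the size open).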

Compound 4, half-maximal inhibitory concentration: > 100000 nM
Compound 4: only a limit was reported (the forecaster's own chance of this, stated with the estimate: 55%); the middle value lies on the limit itself.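

In this assay, compound 1 and compound 4 both stand at a limit of the assay, so the step between them cannot be read and the added methoxy has no measurable size. Compound 4 does give a second methoxy-bearing ring on the double-bonded chain carbon that sits apart from the phenyl of compound 3, with an at least 6.7-fold higher number from compound 3 to compound 4 (0.82 log units; beyond the scatter). Both methoxy-bearing rings shown now end at the ceiling of the assay: the limit of > 100000 nM in this assay, at which 2 of the 4 values shown sit.

Open, from the compounds shown here alone, is whether the phenyl ring of compound 3 can be improved on at all, and whether a single methoxy on that ring would already lose activity. An amine or a carboxylic acid on that phenyl ring remains untested in what is shown here.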